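This account rests on a few compounds, and the source may have more. Where it says the series, first, only, none or still open, it means among the compounds named here.

Compound 1 `NS(=O)(=O)c1ccc(N/C=C\C(=O)c2cc3ccccc3oc2=O)cc1`: 109000 nM
Compound 3 `Cc1cc(NS(=O)(=O)c2ccc(N/C=C\C(=O)c3cc4ccccc4oc3=O)cc2)on1`: 75600 nM
Compound 2 `CC(=O)NS(=O)(=O)c1ccc(N/C=C\C(=O)c2cc3ccccc3oc2=O)cc1`: no result reported

These numbers come from a functional assay on T47D cells (Homo sapiens) for cytotoxicity, read by sulforhodamine B assay, with a stated time of 48 h; a higher number here means a weaker inhibitor, a lower number a stronger inhibitor. Compound 3 holds the lower of the two numbers, but the step of a 1.4-fold lower number from compound 1 to compound 3 (0.16 log units; within the scatter) is within the scatter, so compound 3 and compound 1 cannot be told apart. Compound 4 `Cc1noc(NS(=O)(=O)c2ccc(N/C=C\C(=O)c3cc4ccccc4oc3=O)cc2)c1C` differs from compound 3 by methyl in place of hydrogen on an aromatic carbon. Within the data shown here, no measured step touches this change directly; the one step in hand, which swaps the hydrogen on the sulfonamide nitrogen for the whole five-membered ring, stays within the scatter, so a single added methyl on that ring is expected to move this assay little, in no clear direction. Compound 4 is therefore expected at 70000 nM, between 30000 nM and 160000 nM, the expected step being a 1.1-fold lower number from compound 3 to compound 4 (0.03 log units; within the scatter).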

Compound 4, half-maximal inhibitory concentration: 68400 nM
Compound 4: the middle estimate sits 1.0-fold (0.01 log units) above what was measured, within the range that was stated.
By their numbers in this assay, from the lowest: compounds 4, 3 and 1 (each within the scatter of the next).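

In this assay, a methyl on the aromatic carbon next to the ring atom that bears a large group gives a 1.1-fold lower number from compound 3 to compound 4 (0.04 log units; within the scatter), so this added methyl produces no change that can be told from scatter. Even the full 3,4-dimethyl-1,2-oxazol-5-yl group in place of hydrogen on the sulfonamide nitrogen gives only a 1.6-fold lower number from compound 1 to compound 4 (0.20 log units; within the scatter). No measurement at hand offers an explanation for these results.

Going by these compounds, whether an amine or a carboxylic acid on this same carbon would move the number beyond the scatter remains open.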